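A few compounds are considered here, and "the series" means these few. Any claim that something is new, unique, unknown or untested is made for them only; others in the source may bear on it.

Measured compounds in a functional assay on B16-F10 cells (Mus musculus) for cytotoxicity; a lower number here means a stronger inhibitor, a higher number a weaker inhibitor:

Compound 1 `O=c1oc2ccccc2c2nc3c(ccc4cc[nH]c43)c(-c3cccc(Br)c3)c12` gives 70700 nM.
Compound 2 `O=c1oc2ccccc2c2nc3c(ccc4cc[nH]c43)c(-c3ccccc3Br)c12` gives 70700 nM.
Compound 3 `O=c1cc(O)c2cc(Cl)ccc2o1` gives 70700 nM.

Compound 1 stands level with compounds 2 and 3 at the digits shown; none of the three is separated from another beyond the usual scatter. Compound 4 `COc1ccc(-c2c3ccc4cc[nH]c4c3nc3c2c(=O)oc2ccccc23)cc1` has not yet been measured. It differs from compound 1 as follows: 4-methoxyphenyl in place of 3-bromophenyl on an aromatic carbon.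

For the measured compounds named here, one measured step bears on this change, the exchange of one bromophenyl for another on the same aromatic carbon of the shared core, no change at the digits printed from compound 1 to compound 2 (within the scatter). That step did not move the read-out. On this basis no step beyond the scatter is expected from compound 1 to compound 4, a 1.1-fold lower number from compound 1 to compound 4 (0.04 log units; within the scatter). Compound 4 is therefore estimated at 65000 nM, within a range from 25000 nM to 110000 nM.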

Compound 4, half-maximal inhibitory concentration: 70700 nM
For compound 4 the middle estimate is 1.1-fold (0.04 log units) below the measured one; measured number inside the range.
By their numbers in this assay, from the lowest: compounds 1, 2, 3 and 4 (each within the scatter of the next).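

In this assay the change to 4-methoxyphenyl gives no change at the digits printed from compound 1 to compound 4 (within the scatter) and no change at the digits printed from compound 2 to compound 4 (within the scatter) on this aromatic carbon, opposite the ring nitrogen. The earlier step had only moved the bromine around the phenyl ring, whereas here a different substituent, with one hydrogen-bond acceptor where bromophenyl has none, also leaves the read-out level. No supporting data explain this flat result. Going by these compounds, it remains open whether a phenyl ring carrying an amine or a carboxylic acid at this position would stand apart from these compounds.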